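The source may hold more compounds than are shown below. What is called first, only, known or untested is meant among the compounds shown, and "the series" means these compounds.

Measured compounds:
- compound 1, `COc1cc2c(Oc3ccc(NC(=O)N/N=C/c4ccncc4)cc3F)ccnc2cc1OCCCN1CCCCC1`, 980 nM
- compound 2, `COc1cc2c(Oc3ccc(NC(=O)N/N=C/c4ccc(Cl)cc4Cl)cc3F)ccnc2cc1OCCCN1CCC(C)CC1`, 350 nM
- compound 3, `COc1cc2c(Oc3ccc(NC(=S)N/N=C/c4ccccc4)cc3F)ccnc2cc1OCCCN1CCCCC1`, 710 nM

These three share one core and differ at the outer end of the acylhydrazone arm. In a functional assay on MKN-45 cells (Homo sapiens) for cytotoxicity, read by MTT assay, with a stated time of 72 h (on this read-out lower numbers stand for stronger inhibition and higher numbers for weaker inhibition), compound 3 stands second highest of the three numbers. Its nearest neighbour is compound 1, and the step of a 1.4-fold lower number from compound 1 to compound 3 (0.14 log units; within the scatter) shows that this exchange made no difference beyond the scatter. Compound 2 stands furthest from compound 3, but it differs in more than one place, so nothing can be read from that pair about any single change.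

Compound 4, `COc1cc2c(Oc3ccc(NC(=S)N/N=C/c4ccc(Cl)cc4)cc3F)ccnc2cc1OCCCN1CCCCC1`, follows from compound 3 by one change: chloro in place of hydrogen on an aromatic carbon, para to a large group. Among the compounds with values here, no measured step bears on this change, since no pair among the measured compounds differs only here. Within the data shown here, the only hint is that compound 2, the one carrying chlorine on its outer ring, gives the lowest number, yet it also differs elsewhere. The step of a 1.6-fold lower number from compound 3 to compound 4 (0.20 log units; within the scatter) is therefore an estimate resting on weak ground. Compound 4 is expected to give about 450 nM, within 200 nM to 1000 nM.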

Compound 4, half-maximal inhibitory concentration: 500 nM
Compound 4: the middle estimate sits 1.1-fold (0.05 log units) below what was measured; the measured number falls inside the stated range.
By their numbers in this assay, from the lowest: compounds 2, 4, 3 and 1 (each within the scatter of the next, the first and the last beyond it).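

In this assay, within the data shown here, the step of a 1.4-fold lower number from compound 3 to compound 4 (0.15 log units; within the scatter) isolates phenyl to 4-chlorophenyl, the first change at this position that can be read alone: chloro on this aromatic carbon, para to a large group, shifts the number no more than repeat measurements would. The step of a 2.0-fold lower number from compound 1 to compound 4 (0.29 log units; within the scatter) exchanges the whole outer group and also stays inside the scatter, so even this larger exchange shows no clear effect. Nothing available here offers a reason for either result.

The compounds shown leave open whether a methoxy group or an amine at this same place would move the number beyond the scatter. They also leave open whether chloro behaves the same way when the arm carries a carbonyl instead of a thiocarbonyl.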